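The source may hold more compounds than are shown below. What is called first, only, known or untested is meant among the compounds shown, and "the series" means these compounds.

Measured so far in a physicochemical assay for lipophilicity, read by HPLC, at pH 2; a higher number here means a more lipophilic compound, a lower number a more polar compound:
compound 1 `O=C(O)c1cnn(-c2cccc(-c3cccc(C(=O)N(CC4CC4)CC4CC4)c3F)c2)c1C1CC1`: 3.5
compound 2 `O=C(O)c1cnn(-c2cccc(-c3cccc(C(=O)N4CCCC5(CCCC5)C4)c3F)c2)c1C1CC1`: 3.7
compound 3 `CN(C)C(=O)c1cccc(-c2cccc(-n3ncc(C(=O)O)c3C3CC3)c2)c1F`: 1.3

Compound 3 stands lowest of the three; a number 2.20 log units lower from compound 1 to compound 3 (beyond the scatter) and a number 2.40 log units lower from compound 2 to compound 3 (beyond the scatter) are both large, while a number 0.20 log units higher from compound 1 to compound 2 (within the scatter) is not. Compound 4 `O=C(O)c1cnn(-c2cccc(-c3cccc(C(=O)N4CCCCC4)c3F)c2)c1C1CC1` is not yet measured in this assay. Change from compound 3: piperidin-1-yl in place of dimethylamino on a carbonyl carbon. The two large steps at this carbonyl carbon both bear on it: each leaves a larger amine group from a far higher number, so piperidin-1-yl, with six heavy atoms, should sit between dimethylamino and the larger groups of compounds 1 and 2. An upward step beyond the scatter is therefore expected, a number 1.20 log units higher from compound 3 to compound 4 (beyond the scatter). For compound 4 the estimate in this assay is 2.5, expected between 2.1 and 2.9.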

Compound 4, distribution coefficient: 2.3
Compound 4: the middle estimate sits 0.20 log units above what was measured; measured number inside the range.
By their numbers in this assay, from the lowest: compound 3; then compound 4; then compounds 1 and 2 (each within the scatter of the next).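

At the carbonyl carbon, the amine group now has an intermediate point in this assay: the change to piperidin-1-yl gives a number 1.00 log units higher from compound 3 to compound 4 (beyond the scatter), so the ring separates compound 4 from the dimethylamino amide. The larger groups still stand clear of it, with a number 1.20 log units lower from compound 1 to compound 4 (beyond the scatter) and a number 1.40 log units lower from compound 2 to compound 4 (beyond the scatter), so the piperidin-1-yl amide does not reach the level of either. Nothing available gives a cause for these steps.

Open, as far as these compounds go, is where pyrrolidin-1-yl or morpholin-4-yl would fall at this carbonyl carbon. Also open, from the compounds shown here alone, is whether these steps hold with an ester in place of the carboxylic acid.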